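A few compounds are considered here, and "the series" means these few. Any claim that something is new, unique, unknown or untested is made for them only; others in the source may bear on it.

Measured so far in a functional assay on MDA-MB-231 cells (Homo sapiens) for inhibition, read by MTT assay, with stated times of 18 h and 4 h; on this read-out lower numbers stand for stronger inhibition and higher numbers for weaker inhibition:

- compound 1, `CCCCCCCCCCOP(=O)(O)OCCSC(=S)N1CCCC1` — 67000 nM
- compound 2, `CCCCCCOP(=O)(O)OCCSC(=S)N1CCN(C)CC1` — 73000 nM

Compound 2 gives the highest of the two numbers recorded in this assay; its nearest neighbour is compound 1, whose number is only slightly lower, a gap that sits within the scatter of repeated runs. On these two numbers alone, neither compound can be placed ahead of the other.

Compound 3, `CCCCCCOP(=O)(O)OCCSC(=S)N1CCCC1`, has not yet been measured. Its structure differs from compound 2 as follows: pyrrolidin-1-yl in place of 4-methylpiperazin-1-yl on a thiocarbonyl carbon. Going by the values given here, no step between measured compounds isolates this change, so there is no direct guide to its size. Given that compound 1 and compound 2 sit so close together despite differing at more than one place, the expectation for a 1.0-fold lower number from compound 2 to compound 3 (0.02 log units; within the scatter) is no step beyond the scatter, in either direction. Compound 3 is accordingly estimated at 70000 nM, with a range from 30000 nM to 160000 nM.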

Compound 3, half-maximal inhibitory concentration: 54000 nM
For compound 3 the middle estimate is 1.3-fold (0.11 log units) above the measured one; measured number inside the range.
By their numbers in this assay, from the lowest: compounds 3, 1 and 2 (each within the scatter of the next).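

In this assay, going by these compounds alone, pyrrolidin-1-yl in place of 4-methylpiperazin-1-yl on a thiocarbonyl carbon gives the first isolated reading at this position (a 1.4-fold lower number from compound 2 to compound 3 (0.13 log units; within the scatter)), and this step lies within the scatter, so the exchange of these two rings separates nothing here. Hydrogen in place of butyl on a saturated chain carbon can also now be read on its own (a 1.2-fold lower number from compound 1 to compound 3 (0.09 log units; within the scatter)), and this step too lies within the scatter, so the closeness of the two earlier compounds is not the result of two larger steps in opposite directions. No measurement at hand bears on a cause for these results.

Going by these compounds, it remains open whether a morpholin-4-yl or piperidin-1-yl group on the thiocarbonyl carbon would give a step beyond the scatter. Within the data shown here, the effect of a chain longer than the one in compound 1 also remains open.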